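Trimming the amine-bearing chain to a methylamino group

The compounds below may be only part of what the source reports. "The series", "measured", "known", "first", "only" and "open" are said of these compounds alone.

Compound 1 `COc1ccc(-c2cc(-c3ccc(S(C)(=O)=O)cc3)cnc2NCCCCN)cn1` and compound 2 `COc1ccc(-c2nc(-c3ccc(S(C)(=O)=O)cc3)ccc2N)cn1` share a core and have both been measured in a physicochemical assay for solubility, measured as kinetic solubility, at pH 6.5; on this read-out higher numbers stand for higher solubility and lower numbers for lower solubility. In this assay compound 1 gives 25 ug/mL, and compound 2 gives 25 ug/mL; the two values stand level at the digits shown, within the scatter, so no order between them can be claimed. Compound 3 `CNc1ncc(-c2ccc(S(C)(=O)=O)cc2)cc1-c1ccc(OC)nc1` has not yet been measured. It differs from compound 1 in one place: hydrogen in place of 3-aminopropyl on a saturated chain carbon bound to a nitrogen on an aromatic ring. Among the compounds with values here, no measured pair shows this particular step, so the expectation for compound 3 rests only on the value of compound 1 and on the structural change. The estimate is a step downward in this assay of a 3.1-fold lower number from compound 1 to compound 3 (0.49 log units; beyond the scatter), beyond the scatter. Compound 3 is accordingly expected to give about 8 ug/mL, with a range from 2 ug/mL to 30 ug/mL.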

Compound 3, solubility: 12.5 ug/mL
Compound 3: middle estimate off by 1.6-fold (0.19 log units), on the low side; low and high end bracket the measured number.
By their numbers in this assay, from the lowest: compounds 3, 1 and 2 (each within the scatter of the next).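

In this assay the change of (4-aminobutyl)amino to methylamino, hydrogen in place of 3-aminopropyl on a saturated chain carbon bound to a nitrogen on an aromatic ring, can now be read directly, and the step of a 2.0-fold lower number from compound 1 to compound 3 (0.30 log units; within the scatter) is what this pair gives. At this position, then, the 3-aminopropyl part, with its 4 heavy atoms and its terminal amine, can leave without a step beyond the scatter on this read-out, though this rests on a single pair. Nothing at hand bears on what lies behind this reading.

The compounds shown leave open how a chain of intermediate length ending in an amine, such as 2-aminoethyl, would read in this assay at this position. They also leave open whether a carboxylic acid or a hydroxyl group at the end of the chain would give a step beyond the scatter.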